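Swapping the aryl group on a flat series

The source may report more compounds than this note shows. Statements on the series, on what has been measured and on what is new or still open speak of the compounds shown alone.

Values in a functional assay on microsomes for inhibition, with a stated time of 1 h; on this read-out higher numbers stand for weaker inhibition and lower numbers for stronger inhibition:
- Compound 1 `COc1ccc(-c2nc(SC)n(C)c(=O)c2C#N)cc1`: 53 ug/mL
- Compound 2 `CCOC(=O)c1cnn(-c2nc(-c3ccc(OC)cc3)c(C#N)c(=O)n2C)c1N`: 68 ug/mL
- Compound 3 `CCOC(=O)c1cnn(-c2nc(-c3cccc(OC)c3OC)c(C#N)c(=O)n2C)c1N`: 57 ug/mL

On these numbers, compound 3 cannot be told apart from compound 1 or compound 2, since its gaps to both lie within the usual scatter of repeated measurements. The three compounds therefore form one flat group.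

Compound 4 `CCOC(=O)c1cnn(-c2nc(-c3ccc(N(C)C)cc3)c(C#N)c(=O)n2C)c1N` has not yet been measured. It differs from compound 3 in one place: 4-(dimethylamino)phenyl in place of 2,3-dimethoxyphenyl on an aromatic carbon. In words, 4-(dimethylamino)phenyl stands in place of 2,3-dimethoxyphenyl, on an aromatic carbon ortho to a cyano group.

One measured step changes the aromatic group at this same place: a 1.2-fold lower number from compound 2 to compound 3 (0.08 log units; within the scatter). That step is small and lies within the scatter. Within the data shown here, it is also the only such step, and no measured compound carries a dimethylamino group, so the evidence is thin and the range has to stay wide.

No shift beyond the scatter is expected in this assay, in either direction. The expected change is a 1.0-fold lower number from compound 3 to compound 4 (0.02 log units; within the scatter). For compound 4 the estimated value is 55 ug/mL, with an expected range from 27 ug/mL to 110 ug/mL.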

Compound 4, half-maximal inhibitory concentration: 111 ug/mL
Compound 4: middle estimate off by 2.0-fold (0.30 log units), on the low side, and the stated range ends below it.
By their numbers in this assay, from the lowest: compounds 1, 3, 2 and 4 (each within the scatter of the next, the first and the last beyond it).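

In this assay, among these compounds, 4-(dimethylamino)phenyl brings a nitrogen-bearing group to this aromatic carbon ortho to a cyano group for the first time, and the cleanest reading comes from the swap of dimethylamino for methoxy, which leaves the rest of the molecule untouched: a 1.6-fold higher number from compound 2 to compound 4 (0.21 log units; within the scatter). The wider swap, which also replaces 2,3-dimethoxyphenyl and so changes how the phenyl group is substituted, gives a 1.9-fold higher number from compound 3 to compound 4 (0.29 log units; within the scatter), a step that is still printed as within the scatter even though it comes close to its edge. So exchanging oxygen-linked groups for a nitrogen-linked one on this phenyl group produces no step that can be told apart from repeat-measurement noise, and nothing available explains the numbers.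

Whether any group at this place can move the number beyond the scatter remains open, since every aryl group shown carries only methoxy or dimethylamino. A carboxylic acid, a primary amine or a fluorine on the phenyl group, or a longer chain in place of the methyl groups on the nitrogen, would test this place more widely.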